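Chloro on the phenyl of a thio-pyrimidinone growth inhibitor

The compounds below may be only part of what the source reports. "The series", "measured", "known", "first", "only" and "open" are said of these compounds alone.

Measured compounds:
compound 1 `CCOC(=O)C1=C(C)NC(=S)NC1c1cn(-c2ccccc2)nc1-c1ccccc1`: 42000 nM
compound 2 `CC1=C(C(=O)Nc2ccc(C)cc2)C(c2cn(-c3ccccc3)nc2-c2ccccc2)NC(=S)N1`: 56100 nM
compound 3 `CC1=C(C(=O)Nc2ccc(Cl)cc2)C(c2cn(-c3ccccc3)nc2-c2ccccc2)NC(=S)N1`: 34700 nM

In a functional assay on MCF7 cells (Homo sapiens) for inhibition, read by sulforhodamine B assay, with a stated time of 24 h (on this read-out lower numbers stand for stronger inhibition of growth and higher numbers for weaker inhibition of growth), compound 1 gives 42000 nM, the second highest of the three numbers; its steps to the others, a 1.3-fold higher number from compound 1 to compound 2 (0.13 log units; within the scatter) and a 1.2-fold lower number from compound 1 to compound 3 (0.08 log units; within the scatter), both stay within the scatter, so the three compounds cannot be told apart on these data.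

Compound 4 `CCOC(=O)C1=C(C)NC(=S)NC1c1cn(-c2ccccc2)nc1-c1ccc(Cl)cc1` differs from compound 1 by chloro in place of hydrogen on an aromatic carbon. Among the measured compounds shown here, no measured step makes exactly this exchange. The closest step in kind is a 1.6-fold lower number from compound 2 to compound 3 (0.21 log units; within the scatter), which swaps one small group for chloro on an aromatic carbon in another part of the molecule; it is within the scatter. Since neither that step nor the changes at the carbonyl moved the numbers beyond the scatter, the step to compound 4 is expected to be small as well, in this assay at most a slight lowering, a 1.2-fold lower number from compound 1 to compound 4 (0.08 log units; within the scatter).

Compound 4 is therefore estimated at 35000 nM, with a range from 15000 nM to 85000 nM.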

Compound 4, concentration for 50% growth inhibition: 33200 nM
Estimate against measurement, compound 4: 1.1-fold (0.02 log units) above; measured number inside the range.
By their numbers in this assay, from the lowest: compounds 4, 3, 1 and 2 (each within the scatter of the next).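

The exchange of phenyl for 4-chlorophenyl is the first change shown on the shared core itself rather than on the group at the carbonyl, and it gives a 1.3-fold lower number from compound 1 to compound 4 (0.10 log units; within the scatter) in this assay for this read-out. Chloro at this place, para to a large group, therefore leaves the number within the scatter, as does the exchange of methyl for chloro on the aromatic ring of the amide, seen in a 1.6-fold lower number from compound 2 to compound 3 (0.21 log units; within the scatter) on that other ring. No measurement here bears on how chloro acts at this position.

Still open, on these data alone, is whether a different group at this place, such as methoxy, an amine or a carboxylic acid, would shift the number beyond the scatter. Also open, as far as these compounds go, is whether 4-chlorophenyl on the core would change the number of an amide such as compound 3.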